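The compounds below may be only part of what the source reports. "The series", "measured", "known", "first", "only" and "open" are said of these compounds alone.

Working notes on the series, all read in an ADME assay on BJ cells (Homo sapiens), read by MTT assay, with a stated time of 72 h; on this read-out lower numbers stand for stronger inhibition and higher numbers for weaker inhibition. Compound 1 (`CN(C)c1ncnc2c1c(-c1ccsc1)cn2[C@@H]1O[C@H](CO)[C@@H](O)[C@H]1O`) reports only a limit, > 100000 nM. Going by the values given here, compound 2 (`C#Cc1cn([C@@H]2O[C@H](CO)[C@@H](O)[C@H]2O)c2ncnc(C)c12`) gives a measured 50 nM, the only value so far that is a number rather than a limit. Compound 3 (`COc1nc(N)nc2c1c(-c1ccoc1)cn2[C@@H]1O[C@H](CO)[C@@H](O)[C@H]1O`) also reports only a limit, > 100000 nM. From the compounds shown here alone, compound 3 therefore sits on (the limit of > 100000 nM in this assay, at which 2 of the 3 values shown sit), and its true position beyond that limit is unknown.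

Compound 4 (`COc1nc(N)nc2c1c(-c1cc3ccccc3o1)cn2[C@@H]1O[C@H](CO)[C@@H](O)[C@H]1O`) keeps the core of compound 3 and carries 1-benzofuran-2-yl in place of furan-3-yl on an aromatic carbon of the five-membered aromatic ring with 1 nitrogen: 1-benzofuran-2-yl in place of furan-3-yl on an aromatic carbon. Among the compounds with values here, no measured pair in this set differs in one place only, so the size of this change has no direct precedent here.

The expectation rests on compound 3, whose reading of > 100000 nM is a limit: a small move in this assay towards stronger inhibition is expected, or none that can be seen. The estimated step is an at least 1.4-fold lower number from compound 3 to compound 4 (0.15 log units; that floor lies within the scatter). Compound 4 is expected near 70000 nM, with an estimated range of 15000 nM to 100000 nM, and a reading that is again only a limit is the likeliest outcome.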

Compound 4, half-maximal inhibitory concentration: 25600 nM
For compound 4 the middle estimate is 2.7-fold (0.44 log units) above the measured one; measured number inside the range.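

In this assay, this place on the five-membered aromatic ring with 1 nitrogen now gives its first readable change: 1-benzofuran-2-yl in place of furan-3-yl gives an at least 3.9-fold lower number from compound 3 to compound 4 (0.59 log units; beyond the scatter). Going by these compounds alone, the earlier compounds offered no measured pair differing in one place, so this is the first sign that the group on this aromatic carbon can shift the read-out beyond the scatter, and the larger group here is the one with the lower number. Compound 3 is read only as a limit, so the step has a floor and its full size remains unknown: the limit of > 100000 nM in this assay, at which 2 of the 4 values shown sit.

The step joins two changes, the added six-membered aromatic ring of carbon only and a different point of attachment on the furan, and the compounds shown do not separate them; a furan-2-yl or a phenyl group at this place would bear on that. Also open, from the compounds shown here alone, are how a carboxylic acid or an aminomethyl group would read at this carbon, and whether the same exchange on the core of compound 1 would give a step of similar size.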